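Tolerance in Liver Cells After a Side-Chain Swap

The compounds below may be only part of what the source reports. "The series", "measured", "known", "first", "only" and "open" are said of these compounds alone.

In an ADME assay on HepG2 2.2.15 cells (Homo sapiens) for cytotoxicity (a higher number here means that more compound is tolerated, a lower number that less compound is tolerated), compound 1 `CC(C)(C)OC(=O)Nc1ncc(C(Oc2ccc(Cc3ccccc3)cc2)c2ccc(Cl)cc2)s1` gives only a limit, > 50000 nM. Compound 2 `CCOC(=O)CCCNc1ncc(C(Oc2ccc3cc(Br)ccc3c2)c2ccc(Cl)cc2)s1` is described in this assay as "not toxic" (no number reported), with no number attached to it. Compound 2 therefore stands without a single value in this assay; among the results shown there is the limit of > 50000 nM in this assay, at which 1 of the 2 values shown sits. The step from compound 2 to compound 3 `O=C(Nc1ncc(C(Oc2ccc3cc(Br)ccc3c2)c2ccc(Cl)cc2)s1)c1ccc(F)cc1F` changes ((2,4-difluorophenyl)carbonyl in place of 3-(ethoxycarbonyl)propyl on a nitrogen on an aromatic ring). Within the data shown here, no measured step between related compounds exists here, so the size of this step in this assay can only be anticipated: the expectation is for no change beyond the scatter, with tolerance staying where compound 2 is reported, since compound 2 shows "not toxic" (no number reported) in this assay. Compound 3 is estimated at 60000 nM in this assay, with a range from 20000 nM to 200000 nM, and the result will most likely again be a limit rather than a number.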

Compound 3, half-maximal cytotoxic concentration: "not toxic" (no number reported)
The entry for compound 3 holds no number, so the estimate cannot be set against anything.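

Among these compounds, compound 3 is reported in this assay as "not toxic" (no number reported), as compound 2 was, so no step from compound 2 to compound 3 can be read. The compounds shown leave open how much of either compound the cells would tolerate before any toxicity appeared.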